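Swapping a pyrazole substituent in a glucagon receptor antagonist series

The source may hold more compounds than are shown below. What is called first, only, known or untested is meant among the compounds shown, and "the series" means these compounds.

Three compounds share a core of an aryl ether or amine joined to a benzamide carrying a short acid chain, and each was tested in a functional assay on cells for antagonist activity at Glucagon receptor (Homo sapiens), read by cAMP accumulation, in the presence of a further agent that is not named here; on this read-out lower numbers stand for stronger inhibition and higher numbers for weaker inhibition. Compound 1, `O=C(O)CCNC(=O)c1ccc(C(Oc2ccc(-n3cc(C(F)(F)F)cn3)cc2)C2CC2)cc1`, gives 15000 nM. Compound 3, `CCCC(Nc1cc(C)c(-n2cc(C(F)(F)F)cn2)c(C)c1)c1ccc(C(=O)NCCC(=O)O)cc1`, gives 1400 nM, a lower number than compound 1. Compound 2, `CCCC(Oc1ccc(-n2cc(C(=O)N(C)C)cn2)cc1)c1ccc(C(=O)NCCC(=O)O)cc1`, gives only a limit of the assay, > 30000 nM. That limit is the point at which one of the three values sits (the limit of > 30000 nM in this assay, at which 1 of the 3 values shown sits), so compound 2 stands at the weak end of what has been measured.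

Compound 4, `CCCC(Oc1ccc(-n2cc(F)cn2)cc1)c1ccc(C(=O)NCCC(=O)O)cc1`, differs from compound 2 in a single place: fluoro in place of dimethylcarbamoyl on an aromatic carbon. Among the compounds with values here, no measured pair shows this exact change, so its size can only be guessed from the spread of the three values. Because compound 2 sits at > 30000 nM, any real number for compound 4 would already mean a gain, and the step from compound 2 to compound 4 is expected to be an at least 1.5-fold lower number from compound 2 to compound 4 (0.17 log units; that floor lies within the scatter). Compound 4 is therefore estimated at 20000 nM, within a range from 5000 nM to 60000 nM.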

Compound 4, antagonist equilibrium constant: 10000 nM
Compound 4: middle estimate off by 2.0-fold (0.30 log units), on the high side; measured number inside the range.
By their numbers in this assay, from the lowest: compound 3; then compounds 4 and 1 (each within the scatter of the next). At a limit, above all of these: compound 2.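

Within the data shown here, on this carbon of the pyrazole, two ring bonds from the ring nitrogen, the earlier compounds offered no pair differing in one place, and compound 4 now supplies one: in this assay, putting fluoro in place of dimethylcarbamoyl gives an at least 3.0-fold lower number from compound 2 to compound 4 (0.47 log units; beyond the scatter). The direction of the change is therefore clear, with the compound carrying fluoro on this carbon reading lower than the one carrying dimethylcarbamoyl. The size of the step is only a floor and the real gap could be larger, because compound 2 rests at a limit of the assay rather than at a number: the limit of > 30000 nM in this assay, at which 1 of the 4 values shown sits.

Compounds 1 and 3 carry trifluoromethyl on the pyrazole but differ from compound 4 in other places as well, so the compounds shown do not say how trifluoromethyl and fluoro compare on this carbon. Also open, on these data alone, is how a bare hydrogen, a nitrile or a primary amide on the same carbon would read in this assay, which would help show whether the step comes from losing dimethylcarbamoyl or from gaining fluoro.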